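The compounds below may be only part of what the source reports. "The series", "measured", "known", "first", "only" and "open" are said of these compounds alone.

Measured compounds:
- compound 1 `CC(=O)c1nc([N+](=O)[O-])c(Sc2c(Cl)cccc2Cl)s1`: 19300 nM
- compound 2 `COc1ccc(Sc2sc(C(C)=O)nc2[N+](=O)[O-])cc1OC`: 24000 nM
- compound 3 `O=C(Nc1ccccc1)c1nc([N+](=O)[O-])c(Sc2c(Cl)cncc2Cl)s1`: 12400 nM

Of the compounds shown here, three sharing one core have been tested in a functional assay on HCT-116 cells (Homo sapiens) for antiproliferative activity, read by MTT assay, with a stated time of 72 h; a lower number here means a stronger inhibitor, a higher number a weaker inhibitor. Compound 1 gives 19300 nM, compound 2 gives 24000 nM, and compound 3 gives 12400 nM. Compound 3 has the lowest of the three numbers, but its gaps to compound 1 and to compound 2 both fall within the usual scatter of repeated measurements, so the three cannot be separated on these results.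

Compound 4 `O=C(NCc1ccc(F)cc1)c1nc([N+](=O)[O-])c(Sc2c(Cl)cncc2Cl)s1` has not yet been measured in this assay. It differs from compound 3 in one place: 4-fluorobenzyl in place of phenyl on an amide-type nitrogen. Within the data shown here, no pair of measured compounds shows what a change at this amide-type nitrogen does, so there is nothing here to draw a step from. Given that, the expected step of a 1.0-fold lower number from compound 3 to compound 4 (0.01 log units; within the scatter) is small, with no clear direction beyond the scatter. Compound 4 is estimated to give about 12000 nM in this assay, with a range from 4000 nM to 40000 nM, because compound 3 at 12400 nM is the only anchor available.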

Compound 4, half-maximal inhibitory concentration: 11200 nM
Compound 4: middle estimate off by 1.1-fold (0.03 log units), on the high side; the measured number falls inside the stated range.
By their numbers in this assay, from the lowest: compounds 4, 3, 1 and 2 (each within the scatter of the next, the first and the last beyond it).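

In this assay, among these compounds, the change on the amide-type nitrogen gives the first direct reading at this position, since no earlier pair of compounds differed in one place: a 1.1-fold lower number from compound 3 to compound 4 (0.04 log units; within the scatter). Phenyl and 4-fluorobenzyl differ in size and in the fluorine that the second one carries, yet compound 3 and compound 4 cannot be told apart, so on this pair the nitrogen takes the larger group with no readable gain or loss in the antiproliferative read-out. Nothing available explains why the two compounds match, so the result stands as an observation only.

On these data alone, both groups seen on this nitrogen carry a six-membered aromatic ring of carbon only, so it remains open whether a group without such a ring, such as a simple ethyl chain, a longer chain ending in an amine, or one ending in a carboxylic acid, would give a similar number. Also open, as far as these compounds go, is whether plain benzyl would match 4-fluorobenzyl, which would separate the part played by the fluorine from that of the rest of the group.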